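The source may report more compounds than this note shows. Statements on the series, on what has been measured and on what is new or still open speak of the compounds shown alone.

Compound 1 `c1ccc(-c2nc(-c3c[nH]c4ccccc34)co2)cc1`: 461000 nM in a functional assay on LNCaP cells (Homo sapiens) for cytotoxicity, read by MTT assay, with a stated time of 48 h; on this read-out higher numbers stand for weaker inhibition and lower numbers for stronger inhibition. Compound 2 `Oc1ccc(-c2nc(-c3c[nH]c4ccccc34)co2)cc1`: 449000 nM. Compound 3 `COc1ccc(-c2nc(-c3c[nH]c4ccccc34)co2)cc1`: 507000 nM.

All three share one core. Compound 2 differs from compound 1 by hydroxy in place of hydrogen on an aromatic carbon, a step of a 1.0-fold lower number from compound 1 to compound 2 (0.01 log units; within the scatter). Compound 3 carries methoxy in place of hydrogen on an aromatic carbon, which gave a 1.1-fold higher number from compound 1 to compound 3 (0.04 log units; within the scatter). Compound 4 `COc1cc(-c2nc(-c3c[nH]c4ccccc34)co2)ccc1O`, not yet measured, carries methoxy in place of hydrogen on an aromatic carbon relative to compound 2. For the measured compounds named here, this is the same kind of change as the one from compound 1 to compound 3, but here the group sits ortho to a hydroxy group and meta to a large group rather than para to a large group. A step of about a 1.1-fold higher number from compound 2 to compound 4 (0.03 log units; within the scatter) is expected, resting on the earlier step of a 1.1-fold higher number from compound 1 to compound 3 (0.04 log units; within the scatter) and on all three measured values lying within the scatter of one another. Compound 4 is therefore estimated at 480000 nM, between 240000 nM and 960000 nM.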

Compound 4, half-maximal inhibitory concentration: 445000 nM
Compound 4: the middle estimate sits 1.1-fold (0.03 log units) above what was measured, and the stated range covers the measured number.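

In this assay, methoxy in place of hydrogen on an aromatic carbon gives a 1.0-fold lower number from compound 2 to compound 4 (0.00 log units; within the scatter). Set beside the earlier case, the same change makes no measurable difference on either core: the same change on two cores in this assay, a 1.1-fold higher number (0.04 log units; within the scatter) from compound 1 to compound 3 and a 1.0-fold lower number (0.00 log units; within the scatter) from compound 2 to compound 4, 1.1-fold (0.05 log units) apart, within the scatter of two such steps This agreement shows only that the change left the number in place both times, so it cannot tell whether a step large enough to read would carry from one core to the other, and in compound 4 the methoxy sits ortho to a hydroxy group, which limits the comparison further.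

The compounds shown leave open whether an amine or a carboxylic acid on the same aromatic ring would move the number beyond the scatter. Going by these compounds, whether a longer chain in place of the methyl of the methoxy would do so also remains open.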